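The source may report more compounds than this note shows. Statements on the series, on what has been measured and on what is new or still open speak of the compounds shown alone.

Compound 1 `COc1ccc(Cc2cc(-c3ccc(C)cc3)nn(CC(=O)Nc3ccc(Br)cc3)c2=O)cc1`: in a functional assay on HL-60 cells (Homo sapiens), read by calcium flux (a lower number here means that less compound is needed, a higher number that more compound is needed for the effect), compound 1 gives > 50000 nM, which is a limit of the assay.
Compound 2 `COc1cccc(Cc2cc(-c3ccc(C)cc3)nn(CC(=O)Nc3ccc(F)cc3)c2=O)c1`: in this assay compound 2 gives > 50000 nM, again a limit.
Compound 3 `COc1ccc(Cc2cc(-c3ccc(F)cc3)nn(CC(=O)Nc3ccc(Br)cc3)c2=O)cc1`: in this assay compound 3 gives > 50000 nM, also a limit.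

Compound 1 and compound 3 differ by one change: fluoro in place of methyl on an aromatic carbon. Both values are limits, so the step that the two limits leave unreadable from compound 1 to compound 3 has no readable size; all three measured values sit at the limit of > 50000 nM in this assay, at which 3 of the 3 values shown sit. The difference between the cores of compound 1 and compound 2 is not broken down here.

Compound 4 `COc1cccc(Cc2cc(-c3ccc(F)cc3)nn(CC(=O)Nc3ccc(F)cc3)c2=O)c1` carries the same change relative to compound 2: fluoro in place of methyl on an aromatic carbon, at a place described in the same words. Compound 2 offers only a limit, and the earlier step is unreadable, so the expected step is a step that the limit leaves unreadable from compound 2 to compound 4, resting on compound 3 remaining at its limit > 50000 nM. Compound 4 is therefore expected to give around 60000 nM, between 20000 nM and 200000 nM, most probably reported as a limit again.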

Compound 4, half-maximal effective concentration: > 50000 nM
Compound 4: no number, only a limit; the forecaster's own chance of this, stated with the estimate: 85%; the middle value lies beyond the limit too.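

Compound 2 and compound 4 both sit at a limit of the assay, so no step can be read for the change from 4-methylphenyl to 4-fluorophenyl. The compounds shown leave open which structural change, if any, would give a measurable value in this assay.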